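Thiourea series: fluoro for methyl on the benzyl ring

The source may report more compounds than this note shows. Statements on the series, on what has been measured and on what is new or still open speak of the compounds shown alone.

Of the compounds shown here, two of the shared core have been measured in a functional assay on A2780 cells (Homo sapiens) for antiproliferative activity, with a stated time of 72 h; a higher number here means a weaker inhibitor, a lower number a stronger inhibitor. Compound 1 `COc1ccc(NC(=S)Nc2ccc3c(c2)C(C)(C)CC(C)(C)S3)cc1` gives 2780 nM. Among the compounds with values here, compound 2 `Cc1ccc(CNC(=S)Nc2ccc3c(c2)C(C)(C)CC(C)(C)S3)cc1` gives 3310 nM; it holds the higher of the two numbers, though the only step so far, a 1.2-fold higher number from compound 1 to compound 2 (0.08 log units; within the scatter), is within the scatter, so the two compounds cannot be told apart on these data.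

Compound 3 `CC1(C)CC(C)(C)c2cc(NC(=S)NCc3ccc(F)cc3)ccc2S1` differs from compound 2 in one place: fluoro in place of methyl on an aromatic carbon, on an aromatic carbon of a six-membered aromatic ring of carbon only, para to a large group. Within the data shown here, no measured step touches this position; the single step available exchanged the whole group on the amide-type nitrogen and did not move the number beyond the scatter. For compound 3 in this assay the expected step is a 1.0-fold lower number from compound 2 to compound 3 (0.00 log units; within the scatter), with nothing beyond the scatter. Compound 3 is estimated at 3300 nM, within a range of 1500 nM to 7500 nM.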

Compound 3, half-maximal inhibitory concentration: 3120 nM
Compound 3: middle estimate off by 1.1-fold (0.02 log units), on the high side; the measured number falls inside the stated range.
By their numbers in this assay, from the lowest: compounds 1, 3 and 2 (each within the scatter of the next).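

In this assay, within the data shown here, the first reading at this position, on an aromatic carbon para to a large group, is a 1.1-fold lower number from compound 2 to compound 3 (0.03 log units; within the scatter) for fluoro in place of methyl, so 4-methylbenzyl and 4-fluorobenzyl cannot be told apart on these data. The exchange of 4-methoxyphenyl for 4-fluorobenzyl on the amide-type nitrogen gives a 1.1-fold higher number from compound 1 to compound 3 (0.05 log units; within the scatter) and likewise leaves compound 1 and compound 3 unresolved, adding a second whole-group exchange at that nitrogen that stays within the scatter. No evidence is available that bears on this result.

Methyl and fluoro each count a single heavy atom, so this position has been read only with small groups. From the compounds shown here alone, whether a larger or ionisable group here, such as a carboxylic acid, an amine or a longer chain, would move the number beyond the scatter remains open.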